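A longer ether chain in a series stuck at its limit

This account rests on a few compounds, and the source may have more. Where it says the series, first, only, none or still open, it means among the compounds named here.

In a functional assay on PC-3 cells (Homo sapiens) for antiproliferative activity, with a stated time of 48 h (a lower number here means a stronger inhibitor, a higher number a weaker inhibitor), compound 1 `CCOC(=O)c1cccc(-c2ccc(N(CC)CC)nn2)c1` gives > 25000 nM, which is a limit and not a number. Compound 2 `CCOC(=O)c1ccc(-c2ccc(N(C)C)nn2)cc1` also gives only a limit, > 25000 nM. Compound 3 `CCOC(=O)c1ccc(-c2ccc(OCC)nn2)cc1` likewise stands at a limit, > 25000 nM. The three therefore share one position: the limit of > 25000 nM in this assay, at which 3 of the 3 values shown sit.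

Compound 4 `CCCCOc1ccc(-c2ccc(C(=O)OCC)cc2)nn1` differs from compound 3 by ethyl in place of hydrogen on a saturated chain carbon, two bonds along the chain from an oxygen on an aromatic ring, which turns ethoxy into butoxy. Within the data shown here, the one measured step that touches this group is a step that the two limits leave unreadable from compound 2 to compound 3, so no size carries over from it, and no clear change is expected in this assay. The expected step is an at least 1.2-fold lower number from compound 3 to compound 4 (0.09 log units; that floor lies within the scatter). For compound 4 the estimated value is 20000 nM, with an expected range from 7000 nM to 40000 nM.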

Compound 4, half-maximal inhibitory concentration: > 25000 nM
Compound 4 gave a limit, no number; the forecaster's own chance of this, stated with the estimate: 70%; at least 1.2-fold (0.09 log units) between middle value and limit.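

The steps from compound 2 and compound 3 to compound 4 cannot be read in this assay, since each compound gives only a limit: the limit of > 25000 nM in this assay, at which 4 of the 4 values shown sit. The compounds shown leave open whether butoxy, ethoxy and dimethylamino differ at all.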